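Pyrimidine for methoxypyridine, repeated on a second core

This account rests on a few compounds, and the source may have more. Where it says the series, first, only, none or still open, it means among the compounds named here.

Measured in a functional assay on NCI-H1975 cells (Homo sapiens) for antiproliferative activity, read by MTT assay, with a stated time of 72 h; on this read-out higher numbers stand for weaker inhibition and lower numbers for stronger inhibition:
compound 1 `COc1cc(N(C)C)c(NC(=O)c2ccncc2OC)cc1Nc1nccc(-c2cn(C)c3ccccc23)n1` gives 12100 nM
compound 2 `COc1cc(N(C)C)c(NC(=O)c2ccncn2)cc1Nc1nccc(-c2cn(C)c3ccccc23)n1` gives 1250 nM
compound 3 `COc1cc(N(C)CCN(C)C)c(NC(=O)c2ccncc2OC)cc1Nc1nccc(-c2cn(CCCO)c3ccccc23)n1` gives 1970 nM

Compound 2 differs from compound 1 by pyrimidin-4-yl in place of 3-methoxypyridin-4-yl on a carbonyl carbon, and this change gave a 9.7-fold lower number from compound 1 to compound 2 (0.99 log units; beyond the scatter). Compound 3 carries a different core; the difference between the two cores is not broken down here, and its value sits within the scatter of compound 2 while clearly beyond that of compound 1.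

Compound 4 `COc1cc(N(C)CCN(C)C)c(NC(=O)c2ccncn2)cc1Nc1nccc(-c2cn(CCCO)c3ccccc23)n1` differs from compound 3 by pyrimidin-4-yl in place of 3-methoxypyridin-4-yl on a carbonyl carbon, and the surroundings of the place are the same as before, so this is the same change made on the core of compound 3. For the measured compounds named here, the step is expected to be about a 6.6-fold lower number from compound 3 to compound 4 (0.82 log units; beyond the scatter), resting on the single earlier instance a 9.7-fold lower number from compound 1 to compound 2 (0.99 log units; beyond the scatter) and kept somewhat smaller since only one example supports it. Compound 4 is therefore expected to give roughly 300 nM, estimated between 100 nM and 1000 nM in this assay.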

Compound 4, half-maximal inhibitory concentration: 2120 nM
Estimate against measurement, compound 4: 7.1-fold (0.85 log units) below; the measured number lies above the stated range.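

Made on the second core, the same change gave a 1.1-fold higher number from compound 3 to compound 4 (0.03 log units; within the scatter) in this assay, so on this core the swap shows no effect beyond ordinary assay scatter. The effect of the swap therefore did not carry over from one core to the other: the same change on two cores in this assay, a 9.7-fold lower number (0.99 log units; beyond the scatter) from compound 1 to compound 2 and a 1.1-fold higher number (0.03 log units; within the scatter) from compound 3 to compound 4, 10-fold (1.02 log units) apart, beyond the scatter of two such steps This shows that the result on one core cannot be assumed on the other, but it does not show which of the differences between the cores is responsible, and two pairs give no rule for the series.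

As far as these compounds go, it remains open what the swap would do on a core that carries only one of those differences. From the compounds shown here alone, it is also open how an unsubstituted pyridin-4-yl group would behave on the same carbonyl carbon.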